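Methyl in place of hydrogen, with every value a limit

A few compounds are considered here, and "the series" means these few. Any claim that something is new, unique, unknown or untested is made for them only; others in the source may bear on it.

Measured in a functional assay on the whole organism with Mus musculus as the target; a higher number here means that more compound is needed for the effect, a lower number that less compound is needed:
Compound 1 `CN(c1ccncc1)n1cccc1`: > 20 mg/kg, a limit
Compound 2 `CN(c1ccncc1)n1cccc1Cl`: > 20 mg/kg, a limit
Compound 3 `O=Cc1cccn1Nc1ccncc1`: > 20 mg/kg, a limit

Compound 3 has no exact number of its own in this assay: its > 20 mg/kg is a limit. For the measured compounds named here, the whole series shares a single result, (the limit of > 20 mg/kg in this assay, at which 3 of the 3 values shown sit), so no compound can be ranked against another.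

The next compound is compound 4 `CN(c1ccncc1)n1cccc1C=O`. It differs from compound 3 at one place: methyl in place of hydrogen on a nitrogen on an aromatic ring. Going by the values given here, the only measured step, a step that the two limits leave unreadable from compound 1 to compound 2, is a chloro in place of hydrogen on an aromatic carbon. That is a different change, and it offers no size to carry over.

Compound 1, which carries the same methyl, gives > 20 mg/kg, again a limit. Compound 2, also with that methyl, gives > 20 mg/kg, a limit as well. With no readable step to draw on, no shift of known size or direction can be expected in this assay, and another limit is the most likely report. The expected step is a step that the limit leaves unreadable from compound 3 to compound 4, a figure that rests on no measured size. For compound 4 the estimated value is 30 mg/kg, with an expected range from 12 mg/kg to 80 mg/kg.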

Compound 4, dose for half-maximal effect: > 20 mg/kg
Compound 4 ended at the assay's limit; the forecaster's own chance of this, stated with the estimate: 75%; the middle value is on the limit's open side.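

Compound 4 adds no readable step, since the steps linking it to compound 1, compound 2 and compound 3 in this assay all run between limits and cannot be read: the limit of > 20 mg/kg in this assay, at which 4 of the 4 values shown sit.

The compounds shown leave open how much of any of them is needed for the effect, and whether the methyl, chloro or formyl changes shift that dose at all.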